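The source may report more compounds than this note shows. Statements on the series, on what has been measured and on what is new or still open speak of the compounds shown alone.

Measured so far:
compound 1, `C=CCc1cc(C(C)=O)c(O)cc1OCCCCC`, 23%
compound 2, `C=CCc1cc(C(C)=O)c(O)cc1OCCCCO`, 9%

In an assay on isolated protein for binding affinity to leukotriene B4 receptor 1 (Homo sapiens), tested at 1 uM (a higher number here means more inhibition at the concentration tested (going by the name of the read-out), a lower number less inhibition), compound 2 gives the lower of the two numbers, with compound 1 giving 23%. Going by the values given here, the only measured step bearing on the change is a number 14 percentage points lower from compound 1 to compound 2 (beyond the scatter). Compound 3, `C=CCc1cc(C(C)=O)c(O)cc1OCCCCCC(C)=O`, differs from compound 2 by 2-oxopropyl in place of hydroxy on a saturated chain carbon, four bonds along the chain from an oxygen on an aromatic ring. Among the compounds with values here, since the loss of the hydroxy and the longer chain carry compound 3 back toward compound 1, a modest rise is expected, a number 9 percentage points higher from compound 2 to compound 3 (within the scatter), though no measured pair carries a ketone. Compound 3 is therefore estimated at 18%, between 5% and 35%.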

Compound 3, a percentage reported as inhibition, at one concentration (the size of the read-out at that concentration, not a potency): 58%
Estimate against measurement, compound 3: 40 percentage points below; the measured number lies above the stated range.
By their numbers in this assay, from the lowest: compound 2; then compound 1; then compound 3.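

In this assay the end of this chain proves far more responsive than the first pair suggested: 2-oxopropyl in place of hydroxy brings a number 49 percentage points higher from compound 2 to compound 3 (beyond the scatter) and acetyl in place of hydrogen on the saturated chain carbon brings a number 35 percentage points higher from compound 1 to compound 3 (beyond the scatter). Losing the hydroxy therefore does not account for the whole rise, as the acetyl-bearing chain also stands above the plain chain of compound 1. Nothing measured here explains this gain.

From the compounds shown here alone, whether the carbonyl or the extra chain length carries the rise remains open. A longer plain alkyl chain or a carboxylic acid at the chain end would bear on that question.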